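This account rests on a few compounds, and the source may have more. Where it says the series, first, only, none or still open, it means among the compounds named here.

The measured compounds and their values:

Compound 1, `CC(=O)NS(=O)(=O)c1ccc(N/C(S)=N\c2ccnc3cc(C(F)(F)F)ccc23)cc1`, 30000 nM
Compound 2, `O=S(=O)(Nc1nccs1)c1ccc(N/C(S)=N\c2ccnc3cc(C(F)(F)F)ccc23)cc1`, 67100 nM
Compound 3, `O=S(=O)(Nc1ncccn1)c1ccc(N/C(S)=N\c2ccnc3cc(C(F)(F)F)ccc23)cc1`, 34700 nM

All three share the same core and differ only in the group attached to a sulfonamide nitrogen. In a functional assay on LoVo cells (Homo sapiens) for antiproliferative activity, read by sulforhodamine B assay, with a stated time of 48 h (on this read-out higher numbers stand for weaker inhibition and lower numbers for stronger inhibition), compound 3 sits second highest of the three numbers, but its neighbours lie close: the step of a 1.2-fold higher number from compound 1 to compound 3 (0.06 log units; within the scatter) is within the scatter, and so is a 1.9-fold lower number from compound 2 to compound 3 (0.29 log units; within the scatter). Only a 2.2-fold higher number from compound 1 to compound 2 (0.35 log units; beyond the scatter) reaches beyond the scatter, and modestly.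

Compound 4, `Cc1cc(C)nc(NS(=O)(=O)c2ccc(N/C(S)=N\c3ccnc4cc(C(F)(F)F)ccc34)cc2)n1`, has not yet been measured. It differs from compound 3 in one place: 4,6-dimethylpyrimidin-2-yl in place of pyrimidin-2-yl on a sulfonamide nitrogen. Going by the values given here, no measured step adds methyl groups to a ring on this nitrogen; the measured steps only exchange one group for another, and those exchanges moved this assay by small amounts. With nothing pointing clearly up or down, the expected step in this assay is small, a 1.0-fold higher number from compound 3 to compound 4 (0.00 log units; within the scatter), likely within the scatter. Compound 4 is therefore estimated at 35000 nM, with a plausible range from 15000 nM to 80000 nM.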

Compound 4, half-maximal inhibitory concentration: 40200 nM
Estimate against measurement, compound 4: 1.1-fold (0.06 log units) below, and the stated range covers the measured number.
By their numbers in this assay, from the lowest: compounds 1, 3, 4 and 2 (each within the scatter of the next, the first and the last beyond it).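

Going by these compounds alone, compound 4 carries the first change in this set that adds to a ring on this sulfonamide nitrogen instead of exchanging one group for another. In this assay the two added methyl groups give only a small step (a 1.2-fold higher number from compound 3 to compound 4 (0.06 log units; within the scatter)), and the comparisons with the other two groups also stay within the scatter (a 1.7-fold lower number from compound 2 to compound 4 (0.22 log units; within the scatter); a 1.3-fold higher number from compound 1 to compound 4 (0.13 log units; within the scatter)), so compound 4 falls inside the narrow span already set by compound 1 and compound 2 and does not extend it. No measurement shown here accounts for how little these groups on the nitrogen alter the number.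

From the compounds shown here alone, all four compounds carry either acetyl or an aromatic ring on this nitrogen, so it remains open whether a plain hydrogen there, a small alkyl group such as methyl, or a longer chain ending in an amine would move the number beyond the scatter. Also open, going by these compounds, is whether exchanging the trifluoromethyl group of the shared core for a methoxy group or a chlorine atom would have a larger effect than any change on the sulfonamide nitrogen.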